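The compounds below may be only part of what the source reports. "The series", "measured", "known", "first", "only" and "open" are said of these compounds alone.

Measured compounds:
compound 1, `O=C(NCc1ccccc1)c1cccc(/C=C2\CC(=O)N(c3ccccc3)C2=O)c1`, gives > 100000 nM in an ADME assay on NCM460 cells (Homo sapiens) for cytotoxicity, read by MTT assay, with a stated time of 72 h (a higher number here means a weaker inhibitor, a lower number a stronger inhibitor), a limit of the assay.
compound 2, `O=C(NCC1CCCCC1)c1cccc(/C=C2\CC(=O)N(c3ccccc3)C2=O)c1`, gives > 100000 nM in this assay, likewise a limit of the assay.

Compound 2 thus stands at the limit of this assay, and compound 1 stands at the same limit, so the step that the two limits leave unreadable from compound 1 to compound 2 cannot be read in size or direction. Among the compounds with values here, the one piece of evidence on the measured set is the limit of > 100000 nM in this assay, at which 2 of the 2 values shown sit. The change to compound 3, `O=C(Nc1ccc(Cl)cc1)c1cccc(/C=C2\CC(=O)N(c3ccccc3)C2=O)c1`, is 4-chlorophenyl in place of cyclohexylmethyl on an amide-type nitrogen. No measured step bears readably on this change, so the only expectation that the shown numbers support is that compound 3 remains in the same region as the two limits, with no step beyond the scatter made visible. Compound 3 is therefore estimated at 150000 nM, between 60000 nM and 400000 nM. The step that the limit leaves unreadable from compound 2 to compound 3 is expected to be essentially flat.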

Compound 3, half-maximal inhibitory concentration: > 100000 nM
Compound 3: a limit, no number; the forecaster's own chance of this, stated with the estimate: 80%; the middle value is on the limit's open side.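

In this assay, within the data shown here, compound 3 gives > 100000 nM, a limit of the assay, so no step from compound 1 or compound 2 to compound 3 can be read. The compounds shown leave open whether any group on the amide-type nitrogen would give a readable value in this assay.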